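Reverting from a dichlorinated amide toward a bromophenyl analogue

The source may report more compounds than this note shows. Statements on the series, on what has been measured and on what is new or still open speak of the compounds shown alone.

Within the data shown here, compound 2 `CCN1CCN(c2cc(C)c3cc(NC(=O)c4ccc(Cl)c(Cl)c4)ccc3n2)CC1` holds the only measured number in a functional assay on SK-BR-3 cells (Homo sapiens) for antiproliferative activity, read by MTT assay, with a stated time of 72 h (on this read-out higher numbers stand for weaker inhibition and lower numbers for stronger inhibition), where compound 2 gives 2160 nM. Compound 1 `CCN1CCN(c2cc(C)c3cc(NC(=O)c4ccccc4Cl)ccc3n2)CC1` reaches only a limit in this assay, > 50000 nM. Among the measured compounds shown here, the single measured step, an at least 23-fold lower number from compound 1 to compound 2 (1.36 log units; beyond the scatter), starts from the limit (the limit of > 50000 nM in this assay, at which 1 of the 2 values shown sits). Compound 3 `CCN1CCN(c2cc(C)c3cc(NC(=O)c4ccccc4Br)ccc3n2)CC1` carries the change (2-bromophenyl in place of 3,4-dichlorophenyl on a carbonyl carbon), which brings back a pattern resembling the 2-chlorophenyl of compound 1 and runs that step in reverse. A large rise in the number is therefore expected for compound 3, with a real chance of only a limit. Compound 3 is estimated at 40000 nM, between 8000 nM and 200000 nM. The expected step is a 19-fold higher number from compound 2 to compound 3 (1.27 log units; beyond the scatter).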

Compound 3, half-maximal inhibitory concentration: 39200 nM
For compound 3 the middle estimate is 1.0-fold (0.01 log units) above the measured one, and the stated range covers the measured number.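

In this assay, 2-bromophenyl in place of 3,4-dichlorophenyl on a carbonyl carbon gives an 18-fold higher number from compound 2 to compound 3 (1.26 log units; beyond the scatter), so the weak inhibition is not tied to the 2-chlorophenyl group alone. Compound 1 holds only a limit, > 50000 nM. Bromo in place of chloro on an aromatic carbon gives an at least 1.2-fold lower number from compound 1 to compound 3 (0.10 log units; that floor lies within the scatter), which cannot order the two halogens: the limit of > 50000 nM in this assay, at which 1 of the 3 values shown sits.

The compounds shown leave open whether the lower number needs the 3,4-dichlorophenyl as such, or whether an unsubstituted phenyl, a methoxyphenyl or a pyridine ring on the same carbonyl carbon would hold it.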